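Where compound 4 may land on solubility

This account rests on a few compounds, and the source may have more. Where it says the series, first, only, none or still open, it means among the compounds named here.

Compound 1 `CC(=O)N1CC(CC(=O)NO)(NS(=O)(=O)c2ccc(OCc3cc(C)nc4ccccc34)cc2)C1` gives 800000 nM
Compound 2 `CCc1cc(COc2ccc(S(=O)(=O)NC3(CC(=O)NO)CN(C(C)=O)C3)cc2)c2ccccc2n1` gives 400000 nM
Compound 3 `Cc1cc(COc2ccc(S(=O)(=O)NC3(CC(=O)NO)CC3)cc2)c2ccccc2n1` gives 1600000 nM

All three numbers come from a physicochemical assay for solubility, with a stated time of 24 h, tested at 30 mg/mL (a lower number here means a less soluble compound, a higher number a more soluble compound), and share one core. The number for compound 3 lies within the scatter of compound 1 and beyond the scatter above compound 2.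

Compound 4 `Cc1cc(COc2ccc(S(=O)(=O)NC3(C(=O)NO)CCCCC3)cc2)c2ccccc2n1` has not been measured yet. The change from compound 3 is a group of 10 heavy atoms (7 carbon, 1 nitrogen, 2 oxygen; one six-membered non-aromatic ring of carbon only) in place of a group of 8 heavy atoms (5 carbon, 1 nitrogen, 2 oxygen; one three-membered non-aromatic ring of carbon only), on a sulfonamide nitrogen (the group with the larger carbon count enters). Going by the values given here, no measured step makes this change. Among the compounds with values here, only one step bears on it, and loosely: methyl in place of hydrogen gave a 2.0-fold lower number from compound 1 to compound 2 (0.30 log units; within the scatter) and that step sits at a different place in the molecule. It also adds carbon, so a lower number is the likelier direction, but the evidence is thin.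

The expected change is a 4.0-fold lower number from compound 3 to compound 4 (0.60 log units; beyond the scatter) in this assay and this size is only an estimate. Compound 4 is therefore expected at 400000 nM (estimated range 80000 nM to 1600000 nM).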

Compound 4, solubility: 11000000 nM
For compound 4 the middle estimate is 28-fold (1.44 log units) below the measured one; measured number above the stated range.
By their numbers in this assay, from the lowest: compounds 2, 1 and 3 (each within the scatter of the next, the first and the last beyond it); then compound 4.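

In this assay, placing the group with the six-membered ring of carbon only on the sulfonamide nitrogen, where compound 3 carries the group with the three-membered ring of carbon only, gives a 6.9-fold higher number from compound 3 to compound 4 (0.84 log units; beyond the scatter). This is the first step shown at this position, and it adds carbon yet raises the number beyond the scatter, whereas the step at a different place gave a 2.0-fold lower number from compound 1 to compound 2 (0.30 log units; within the scatter), so carbon count alone does not follow the number across these two steps. Nothing shown explains the rise.

The two groups differ as whole groups, so this single step cannot show which part of the change matters. On these data alone, it also remains open how this assay would read with an amine or a carboxylic acid on the ring at this position.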